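One Triazole for Another: From Compound 1 to Compound 4

A few compounds are considered here, and "the series" means these few. Any claim that something is new, unique, unknown or untested is made for them only; others in the source may bear on it.

Measured compounds:
compound 1, `Cc1cc(C)c(NC(=O)N(Cc2ccc(-c3n[nH]c(C)n3)cc2)C2CCCCCC2)c(C)c1`, > 1 mg/kg
compound 2, `CSc1cc(C)nc(SC)c1NC(=O)N(Cc1ccccc1)Cc1cccc(-c2cc[nH]n2)c1`, 0.046 mg/kg
compound 3, `Cc1cc(C)c(NC(=O)N(Cc2cccc(-n3cccc3)c2)C2CCCCCC2)c(C)c1`, 0.17 mg/kg

In a functional assay on a cell-free system (plasma) with sterol O-acyltransferase, Soat (Rattus norvegicus) as the target (a lower number here means that less compound is needed, a higher number that more compound is needed for the effect), compound 1 gives > 1 mg/kg, and this is a limit of the assay rather than a number. Compound 1 therefore sits at the limit of > 1 mg/kg in this assay, at which 1 of the 3 values shown sits, the one entry of the three that is a limit and not a measured value. In this assay, for the measured compounds named here, compound 2 gives 0.046 mg/kg and compound 3 gives 0.17 mg/kg, both of them measured values; since no single-point step connects compound 2 or compound 3 to compound 1, these two values only show where measured members of the set lie.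

Compound 4, `Cc1cc(C)c(NC(=O)N(Cc2ccc(-n3ccnn3)cc2)C2CCCCCC2)c(C)c1`, has not yet been measured. It differs from compound 1 in one place: 1H-1,2,3-triazol-1-yl in place of 5-methyl-1H-1,2,4-triazol-3-yl on an aromatic carbon. Going by the values given here, no measured pair in this set isolates this change, so the expected size of the step in this assay rests on the limit of compound 1 alone. Since compound 1 shows only > 1 mg/kg, any estimate for compound 4 is expected to carry a wide range and a fair chance of another limit. Compound 4 is estimated at 0.6 mg/kg, between 0.1 mg/kg and 3 mg/kg, which would be an expected step of an at least 1.6-fold lower number from compound 1 to compound 4 (0.22 log units; that floor lies within the scatter).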

Compound 4, dose for half-maximal effect: > 1 mg/kg
Compound 4: no number, only a limit; the forecaster's own chance of this, stated with the estimate: 40%; at least 1.6-fold (0.22 log units) between middle value and limit.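

Compound 1 and compound 4 both end at a limit in this assay rather than at a number, so no step between them can be read: the limit of > 1 mg/kg in this assay, at which 2 of the 4 values shown sit.

The compounds shown leave open how far each of the two lies beyond that limit, and whether 1H-1,2,3-triazol-1-yl or 5-methyl-1H-1,2,4-triazol-3-yl gives the lower number.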